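Swapping the Sulfonamide Arm for a Difluorophenyl Ring

This account rests on a few compounds, and the source may have more. Where it says the series, first, only, none or still open, it means among the compounds named here.

Of the compounds shown here, three sharing one core have been measured. Compound 1 `O=C1O[C@H]([C@@H](O)Cn2cc(-c3ccc(Br)cc3)nn2)C(OCc2ccccc2)=C1OCc1ccccc1` gives 5100 nM in an ADME assay on HFF cells (Homo sapiens) for cytotoxicity, read by MTT assay, with a stated time of 72 h; a lower number here means a stronger inhibitor, a higher number a weaker inhibitor. Compound 2 `O=C1O[C@H]([C@@H](O)Cn2cc(-c3cccc(O)c3)nn2)C(OCc2ccccc2)=C1OCc1ccccc1` gives 39000 nM. Compound 3 `O=C1O[C@H]([C@@H](O)Cn2cc(CNS(=O)(=O)c3ccc(Cl)cc3)nn2)C(OCc2ccccc2)=C1OCc1ccccc1` gives 20 nM, the lowest of the three numbers. The step of a 260-fold lower number from compound 1 to compound 3 (2.41 log units; beyond the scatter) and the step of a 2000-fold lower number from compound 2 to compound 3 (3.29 log units; beyond the scatter) both show that its arm goes with far stronger cytotoxicity than a phenyl group placed directly on the five-membered ring. Compound 4 `O=C1O[C@H]([C@@H](O)Cn2cc(-c3cc(F)cc(F)c3)nn2)C(OCc2ccccc2)=C1OCc1ccccc1` differs from compound 3 in one place: 3,5-difluorophenyl in place of (((4-chlorophenyl)sulfonyl)amino)methyl on an aromatic carbon. In build it returns to the pattern of compounds 1 and 2, with compound 1 the closer match. A large step in the opposite direction is therefore expected, a 250-fold higher number from compound 3 to compound 4 (2.40 log units; beyond the scatter). Compound 4 is estimated at 5000 nM, most likely between 1500 nM and 20000 nM.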

Compound 4, half-maximal inhibitory concentration: > 100000 nM
Compound 4 ended at the assay's limit; the forecaster's own chance of this, stated with the estimate: 5%; at least 20-fold (1.30 log units) between middle value and limit.
By their numbers in this assay, from the lowest: compound 3; then compound 1; then compound 2. At a limit, above all of these: compound 4.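

Compound 4 ended at a limit of the assay, not at a number: the limit of > 100000 nM in this assay, at which 1 of the 4 values shown sits. Each step to it is therefore a minimum, and the largest is the loss of the sulfonamide arm (an at least 5000-fold higher number from compound 3 to compound 4 (3.69 log units; beyond the scatter)), with an at least 19-fold higher number from compound 1 to compound 4 (1.29 log units; beyond the scatter) and an at least 2.5-fold higher number from compound 2 to compound 4 (0.40 log units; beyond the scatter) as the smaller ones. So the choice of phenyl group at this carbon of the five-membered ring matters in its own right, since compound 4 lies beyond both other phenyl compounds. Going by these compounds, how far beyond the limit compound 4 lies stays unknown. Also open, on these data alone, is whether a plain aminomethyl group or a carboxylic acid at this carbon would sit nearer compound 3 or compound 4.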